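A few compounds are considered here, and "the series" means these few. Any claim that something is new, unique, unknown or untested is made for them only; others in the source may bear on it.

Three compounds carry numbers in a functional assay with growth hormone secretagogue receptor type 1 (Homo sapiens) as the target; on this read-out lower numbers stand for smaller maximal responses and higher numbers for larger maximal responses:
compound 1 `COc1cc2c(cc1N1C[C@@H](C)N[C@@H](C)C1)N(S(=O)(=O)Cc1cccc(I)c1)CC2` gives 0.8;
compound 2 `COc1cc2c(cc1N1C[C@@H](C)N[C@@H](C)C1)N(S(=O)(=O)CCc1ccccc1Cl)CC2` gives 0.9;
compound 3 `COc1cc2c(cc1N1CCN[C@@H](C)C1)N(S(=O)(=O)c1ccc(-c3ccccn3)s1)CC2` gives 1.

Compound 3 stands highest of the three. Its gap to compound 2 lies within the scatter, so the two cannot be ranked; its gap to compound 1 lies beyond it.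

Compound 4 `COc1cc2c(cc1N1C[C@@H](C)NC(C)(C)C1)N(S(=O)(=O)c1ccc(-c3ccccn3)s1)CC2` is the next entry. Relative to compound 3 the change is a group of 9 heavy atoms (7 carbon, 2 nitrogen; one six-membered non-aromatic ring with 2 hetero atoms) in place of a group of 7 heavy atoms (5 carbon, 2 nitrogen; one six-membered non-aromatic ring with 2 hetero atoms), on an aromatic carbon. Among the compounds with values here, the only step recorded so far, a number 0.10 higher from compound 1 to compound 2 (within the scatter), concerns the group on the saturated chain carbon bound to the sulfonyl sulfur and is within the scatter; it does not touch the ring that is exchanged here. Within the data shown here, no measured pair therefore speaks to the change from compound 3 to compound 4, and the one step available shows the read-out to move little under a single substitution in this set.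

Accordingly, the expected step is a number 0.050 lower from compound 3 to compound 4 (within the scatter), none beyond the scatter. Compound 4 is estimated at 0.95, with a range from 0.8 to 1.1.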

Compound 4, intrinsic activity: the largest response reached, as a fraction of the reference agonist's: 0.8
Estimate against measurement, compound 4: 0.15 above; measured number inside the range.
By their numbers in this assay, from the lowest: compounds 1, 4, 2 and 3 (each within the scatter of the next, the first and the last beyond it).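

At this aromatic carbon, ortho to a methoxy group, exchanging 3-methylpiperazin-1-yl for the more substituted six-membered ring of 9 heavy atoms gives a number 0.20 lower from compound 3 to compound 4 (beyond the scatter) in this assay. Within the data shown here, this is the first step to lie beyond the scatter, so the amine ring at this position can change the maximal response even though the two groups have the same hydrogen-bond donor and acceptor counts and no net charge. Nothing measured on these compounds accounts for the lower number.

The compounds shown do not tell whether an unsubstituted piperazin-1-yl or a morpholin-4-yl at this carbon would keep or lower the response. As far as these compounds go, whether the same exchange gives a similar step with a sulfonyl group other than that shared by compound 3 and compound 4 also remains open.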